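From Chloromethyl to 1-Chloroethyl on the Shared Core

A few compounds are considered here, and "the series" means these few. Any claim that something is new, unique, unknown or untested is made for them only; others in the source may bear on it.

Three esters built on one saturated core have been measured in a physicochemical assay for lipophilicity, measured as octanol-water partition; on this read-out higher numbers stand for higher lipophilicity and lower numbers for lower lipophilicity. Compound 1 `CC(C)[C@@H]1CC[C@@H](C)C[C@H]1OC(=O)CCl` carries the smallest ester group of the three, compound 2 `CC(C)[C@@H]1CC[C@@H](C)C[C@H]1OC(=O)/C=C/c1ccc([N+](=O)[O-])cc1` and compound 3 `CC(C)[C@@H]1CC[C@@H](C)C[C@H]1OC(=O)c1ccc(Br)cc1` each carry a larger aromatic one. In this assay compound 1 gives 3.5, the lowest of the three numbers. Compound 2 gives 5.18 and compound 3 gives 5.61, both well beyond the scatter above compound 1. Among the measured compounds shown here, no pair of measured compounds differs in only one place, so no single step can be read off directly.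

Compound 4 `CC(Cl)C(=O)O[C@@H]1C[C@H](C)CC[C@H]1C(C)C` is the next compound to be measured. It differs from compound 1 by methyl in place of hydrogen on a saturated chain carbon bound to a carbonyl carbon and a chlorine atom. Nothing leaves but a hydrogen and only one carbon enters, so the expected step is small and upward, a number 0.50 log units higher from compound 1 to compound 4 (beyond the scatter), roughly at the edge of the scatter. On that basis compound 4 is estimated at 4, with a range from 3.6 to 4.4.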

Compound 4, partition coefficient: 4.04
Compound 4: the middle estimate sits 0.04 log units below what was measured, and the stated range covers the measured number.
By their numbers in this assay, from the lowest: compound 1; then compound 4; then compound 2; then compound 3.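

Among the compounds shown here, compound 4 gives the first step in this set that can be read at a single place: in this assay, methyl in place of hydrogen on a saturated chain carbon bound to a carbonyl carbon and a chlorine atom gives a number 0.54 log units higher from compound 1 to compound 4 (beyond the scatter), a modest change. The read-out at this position therefore responds to the entry of one carbon, with the chlorine and the shared core unchanged. Nothing at hand explains why the number moves, so the step stands as an observation only.

The compounds shown leave open whether a longer chain, such as 1-chloropropyl, would extend the step in the same direction. They also leave open what an amine or a hydroxyl group in place of the chlorine would do at this carbon.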